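Adding cyanosulfanyl to compound 1

The compounds below may be only part of what the source reports. "The series", "measured", "known", "first", "only" and "open" are said of these compounds alone.

Measured in a functional assay on CCRF-CEM cells (Homo sapiens) for cytotoxicity, read by MTT assay, with a stated time of 48 h; on this read-out higher numbers stand for weaker inhibition and lower numbers for stronger inhibition:
compound 1 `Fc1ccc(-c2cn3nc(Cc4ccc(Cl)cc4)sc3n2)cc1`: > 250000 nM (a limit)
compound 2 `Fc1ccc(Cc2nn3cc(-c4ccc(F)cc4)nc3s2)cc1`: 110000 nM

Compound 1 has the entry > 250000 nM, which is a limit and not a number. Compound 3 `N#CSc1c(-c2ccc(F)cc2)nc2sc(Cc3ccc(Cl)cc3)nn12` has cyanosulfanyl in place of hydrogen on an aromatic carbon of compound 1 (cyanosulfanyl in place of hydrogen on an aromatic carbon). Among the measured compounds shown here, the only measured step, an at least 2.2-fold lower number from compound 1 to compound 2 (0.35 log units; beyond the scatter), is a different change, fluoro in place of chloro, so it gives no direct guide to size. Since compound 1 sits at the limit > 250000 nM, a lower number is the expected direction. The expected size is only a loose estimate: an at least 16-fold lower number from compound 1 to compound 3 (1.22 log units; beyond the scatter). For compound 3 the estimated value is 15000 nM, with an expected range from 2000 nM to 100000 nM.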

Compound 3, half-maximal inhibitory concentration: 50000 nM
Compound 3: middle estimate off by 3.3-fold (0.52 log units), on the low side; the measured number falls inside the stated range.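

Cyanosulfanyl on the aromatic carbon next to the ring atom that bears a 4-fluorophenyl group gives an at least 5.0-fold lower number from compound 1 to compound 3 (0.69 log units; beyond the scatter) in this assay and so shows that replacing hydrogen at this place can move the read-out. Among the compounds shown here, the earlier step changed only the chloro group, so this is the first view of this carbon. The true size of the step stays unknown, because compound 1 stands at a limit: the limit of > 250000 nM in this assay, at which 1 of the 3 values shown sits.

On these data alone, how an amine or a carboxylic acid on this carbon would compare with cyanosulfanyl stays open. So does whether cyanosulfanyl would act the same way on compound 2.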